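Working notes: compound 3 to compound 4

The compounds below may be only part of what the source reports. "The series", "measured", "known", "first", "only" and "open" are said of these compounds alone.

Compound 1 `C=C[C@@](C)(/C=C/c1ccc(O)c(C=O)c1)CCC=C(C)C`: > 36600 nM (a limit)
Compound 2 `C=C[C@@](C)(/C=C/c1ccc(O)c(/C=C/C(=O)c2ccccc2)c1)CCC=C(C)C`: > 7410 nM (a limit)
Compound 3 `C=C[C@@](C)(/C=C/c1ccc(O)c(/C=C/C#N)c1)CCC=C(C)C`: > 36600 nM (a limit)

All three entries come from an ADME assay on HEK293 cells (Homo sapiens) for cytotoxicity, with a stated time of 72 h (a lower number here means that less compound is needed, a higher number that more compound is needed for the effect), and none of them is a measured number. Compound 3 stands only at a limit, > 36600 nM. The series sits at two limits: the limit of > 36600 nM in this assay, at which 2 of the 3 values shown sit, and (the limit of > 7410 nM in this assay, at which 1 of the 3 values shown sits).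

The next compound is compound 4 `C=C[C@@](C)(/C=C/c1ccc(O)c(/C=C/C(=O)OCC)c1)CCC=C(C)C`, not yet measured in this assay. Its difference from compound 3 is ethoxycarbonyl in place of cyano on a double-bonded chain carbon bound to a double-bonded chain carbon.

Among the compounds with values here, two measured steps bear on this change: a step that the two limits leave unreadable from compound 1 to compound 3, and a step that the two limits leave unreadable from compound 2 to compound 3. Neither has a readable size, so neither gives a direction for the incoming group. Compound 2 carries benzoyl at the same place and gave only a limit, > 7410 nM. On that basis, no step beyond the scatter is expected in this assay, and a further limit is the most likely report. The estimated change is an at least 1.4-fold lower number from compound 3 to compound 4 (0.16 log units; that floor lies within the scatter). The expected value for compound 4 is 25000 nM, with an estimated range of 8000 nM to 60000 nM.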

Compound 4, half-maximal effective concentration: > 36600 nM
Compound 4: no number, only a limit; the forecaster's own chance of this, stated with the estimate: 80%; middle value at least 1.4-fold (0.16 log units) from the limit.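

Within the data shown here, compound 4 gives only a limit in this assay, > 36600 nM, so its steps to compound 1, compound 2 and compound 3 cannot be read and no new step follows. The compounds shown leave open whether the groups that differ among compound 1, compound 2, compound 3 and compound 4 change the measured concentration at all in this assay.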